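The source may report more compounds than this note shows. Statements on the series, on what has been measured and on what is new or still open speak of the compounds shown alone.

In a physicochemical assay for lipophilicity, read by HPLC, using the shake flask method, measured as octanol-water partition, at pH 7.4 (a higher number here means a more lipophilic compound, a lower number a more polar compound), compound 1 (`Cc1cc2ncccc2cc1Nc1ncc2c(n1)n(C1CCOCC1)c(=O)n2C`) gives 2.5, compound 2 (`Cc1cc2ncccc2cc1Nc1ncc2c(n1)n([C@@H]1CCN(C)C1)c(=O)n2C`) gives 1.2 and compound 3 (`Cc1cc2ncccc2cc1Nc1ncc2c(n1)n([C@H]1CCN(C)C1)c(=O)n2C`) gives 1.1. What separates the last two is the fact that compounds 2 and 3 differ only in the configuration as drawn, and the measured step is a number 0.10 log units lower from compound 2 to compound 3 (within the scatter). Compound 3 therefore stands level with compound 2, and well away from compound 1, as the step of a number 1.40 log units lower from compound 1 to compound 3 (beyond the scatter) shows. The matching step with the other configuration is a number 1.30 log units lower from compound 1 to compound 2 (beyond the scatter). Both steps put 1-methylpyrrolidin-3-yl in place of oxan-4-yl on an aromatic nitrogen.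

Compound 4 (`Cc1cc2ncccc2cc1Nc1ncc2c(n1)n([C@H]1CCN(C3COC3)C1)c(=O)n2C`) has oxetan-3-yl in place of methyl on an amine nitrogen in a ring. For the measured compounds named here, no measured step changes this group directly, so the large steps from compound 1 give only a loose guide. A moderate rise in this assay is expected, recovering part of the gap between compound 3 at 1.1 and compound 1 at 2.5. The expected change is a number 0.80 log units higher from compound 3 to compound 4 (beyond the scatter). Compound 4 is estimated at 1.9, with an expected range of 1.4 to 2.4.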

Compound 4, distribution coefficient: 1.5
For compound 4 the middle estimate is 0.40 log units above the measured one; low and high end bracket the measured number.
By their numbers in this assay, from the lowest: compounds 3, 2 and 4 (each within the scatter of the next, the first and the last beyond it); then compound 1.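

For the compounds shown here, with the configuration held, putting oxetan-3-yl in place of methyl on the amine nitrogen in the ring gives in this assay a first reading of this position, a number 0.40 log units higher from compound 3 to compound 4 (beyond the scatter), while the comparison with the other configuration gives a number 0.30 log units higher from compound 2 to compound 4 (within the scatter), so only the first of these two readings stands clear of the scatter. The replacement closes only part of the gap to the oxan-4-yl compound, as a number 1.00 log units lower from compound 1 to compound 4 (beyond the scatter) still shows. Nothing measured here accounts for the size of this step.

The compounds shown leave open how other groups on this amine nitrogen, such as an acetyl group or a 2-methoxyethyl chain, would read in this assay. They also leave open what oxetan-3-yl gives on the configuration drawn in compound 2.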